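Replacing pyridin-2-yl with 1-(methylsulfonyl)piperidin-4-yl

The source may hold more compounds than are shown below. What is called first, only, known or untested is meant among the compounds shown, and "the series" means these compounds.

In a physicochemical assay for solubility, in phosphate buffer, at pH 7.4 (on this read-out higher numbers stand for higher solubility and lower numbers for lower solubility), compound 3 (`c1ccc(-c2nccnc2OC2CN(c3ccc4ccccc4n3)C2)nc1`) gives 349000 nM and so lies within the scatter of compound 1 (`CN(C)C1CCN(c2nccnc2OC2CN(c3ccc4ccccc4n3)C2)CC1`), which gives 500000 nM as its number, while compound 2 (`NC(=O)C1CCN(c2nccnc2OC2CN(c3ccc4ccccc4n3)C2)CC1`) gives 14000 nM on the same read-out. Compound 4 (`CS(=O)(=O)N1CCC(c2nccnc2OC2CN(c3ccc4ccccc4n3)C2)CC1`) follows from compound 3 by a single change on the shared core: 1-(methylsulfonyl)piperidin-4-yl in place of pyridin-2-yl on an aromatic carbon. Two measured steps exchange a non-aromatic six-membered ring at this place for pyridin-2-yl. The first is a 1.4-fold lower number from compound 1 to compound 3 (0.16 log units; within the scatter) and the second, a large one, is a 25-fold higher number from compound 2 to compound 3 (1.40 log units; beyond the scatter) in this read-out. The outcome with such a ring therefore depends on what it carries, as a 36-fold lower number from compound 1 to compound 2 (1.55 log units; beyond the scatter) shows directly. Compound 4 has no dimethylamino group, so the expectation leans towards compound 2 with its 14000 nM reading. A large fall is expected, estimated as a 14-fold lower number from compound 3 to compound 4 (1.14 log units; beyond the scatter) in size. Expected for compound 4 is 25000 nM with a range from 6000 nM to 100000 nM once measured.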

Compound 4, solubility: 181000 nM
For compound 4 the middle estimate is 7.2-fold (0.86 log units) below the measured one; measured number outside the range, above it.
By their numbers in this assay, from the lowest: compound 2; then compounds 4, 3 and 1 (each within the scatter of the next, the first and the last beyond it).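

In this assay, the change to 1-(methylsulfonyl)piperidin-4-yl stays within the scatter, at a 1.9-fold lower number from compound 3 to compound 4 (0.29 log units; within the scatter), so this position accepts a non-aromatic six-membered ring with a reading that cannot be told apart from that of the pyridin-2-yl group. Compound 4 has no dimethylamino group, yet the gap to the carbamoyl compound is large, at a 13-fold higher number from compound 2 to compound 4 (1.11 log units; beyond the scatter), so the absence of dimethylamino does not by itself bring a compound down to the reading of compound 2. The dimethylamino compound keeps only a modest margin, at a 2.8-fold lower number from compound 1 to compound 4 (0.44 log units; beyond the scatter), which leaves compound 2 alone at the low end of these four.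

Nothing available here explains these differences. On these data alone, compounds 2 and 4 differ both in the group carried and in how the ring is attached, so it remains open which of the two goes with the low reading, and a 1-carbamoylpiperidin-4-yl group at this place would separate them.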